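A few compounds are considered here, and "the series" means these few. Any claim that something is new, unique, unknown or untested is made for them only; others in the source may bear on it.

Of the compounds shown here, three that share one core have been tested in a functional assay on cells (Platelet, Homo sapiens) for inhibition (on this read-out higher numbers stand for weaker inhibition and lower numbers for stronger inhibition), and every one of them stopped at the limit of the method. Compound 1 `NC(=O)c1ccc(-c2nn(Cc3ccccc3)c3ccccc23)cc1` gives > 10000 nM in this assay, a limit rather than a number. Compound 2 `OCc1ccc(-c2nn(Cc3ccccc3)c3ccccc23)cc1` likewise gives > 10000 nM in this assay, again a limit. Compound 3 `CO/N=C\c1ccc(-c2nn(Cc3ccccc3)c3ccccc23)cc1` gives > 10000 nM in this assay, once more a limit and not a measured value. Because of the limit of > 10000 nM in this assay, at which 3 of the 3 values shown sit, none of the steps among them can be read: the step that the two limits leave unreadable from compound 1 to compound 3 and the step that the two limits leave unreadable from compound 2 to compound 3 are both hidden, as is the step that the two limits leave unreadable from compound 1 to compound 2.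

Compound 4 `CCOC(=O)/C=C/c1ccc(-c2nn(Cc3ccccc3)c3ccccc23)cc1` carries the change (a group of 7 heavy atoms (5 carbon, 2 oxygen; no ring) in place of a group of 4 heavy atoms (2 carbon, 1 nitrogen, 1 oxygen; no ring), on an aromatic carbon). The two steps that end at compound 3 give no size, so nothing measured here points to any direction for this change, and the only expectation that the three limits support is that compound 4 also fails to reach the range where a number is reported. The step expected in this assay is a step that the limit leaves unreadable from compound 3 to compound 4, understood as an estimate with wide uncertainty. For compound 4 the value in this assay is therefore estimated at 15000 nM, within 3000 nM to 60000 nM, most likely to be returned as a limit.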

Compound 4, half-maximal inhibitory concentration: > 10000 nM
Compound 4: a limit, no number (the forecaster's own chance of this, stated with the estimate: 80%); the middle value does not contradict the limit.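

In this assay compound 4 gives > 10000 nM, a limit and not a number. The steps to compound 4 from compound 1, compound 2 and compound 3 therefore cannot be read, because they all end at the same limit: the limit of > 10000 nM in this assay, at which 4 of the 4 values shown sit.

The compounds shown leave open whether any group in this place on the shared core gives a measurable inhibition.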